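A Dimethylamino Propyl Chain on the Phenol of Compound 2

This account rests on a few compounds, and the source may have more. Where it says the series, first, only, none or still open, it means among the compounds named here.

Compound 2 `COc1ccc(Cc2nc(-c3cc(Br)c(O)c(Br)c3)c[nH]c2=O)cc1Br` carries a free hydroxy group on one of its aromatic rings. In a functional assay on THP-1 cells (Homo sapiens) for inhibition, read by MTT assay, with a stated time of 24 h (a higher number here means a weaker inhibitor, a lower number a stronger inhibitor), compound 2 gives 125000 nM. Its number is the highest of the three measured here, though the gaps to its neighbours are small: compound 3 `COc1ccc(Cc2nc(-c3cc(Br)c(O)c(Br)c3)cnc2Cl)cc1Br` gives 108000 nM, and compound 1 `CNCCCOc1c(Br)cc(-c2c[nH]c(=O)c(Cc3ccc(OC)c(Br)c3)n2)cc1Br` gives 90700 nM, and both differences from compound 2 lie within the usual scatter.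

The step to compound 4 `COc1ccc(Cc2nc(-c3cc(Br)c(OCCCN(C)C)c(Br)c3)c[nH]c2=O)cc1Br` puts a chain on that oxygen: 3-(dimethylamino)propyl in place of hydrogen on an oxygen on an aromatic ring.

One measured step speaks to this change. Going from compound 1 to compound 2 removed a closely related chain from the same oxygen, and that step was a 1.4-fold higher number from compound 1 to compound 2 (0.14 log units; within the scatter). Adding the 3-(dimethylamino)propyl chain in compound 4 reverses that kind of change, with one more methyl on the nitrogen. For the measured compounds named here, the only evidence therefore points to a small step, if any, toward a lower number, and nothing beyond the scatter should be expected.

Compound 4 is accordingly estimated at 95000 nM, with a plausible range from 45000 nM to 200000 nM. This estimate corresponds to an expected step of a 1.3-fold lower number from compound 2 to compound 4 (0.12 log units; within the scatter), because the comparable step a 1.4-fold higher number from compound 1 to compound 2 (0.14 log units; within the scatter) was itself within the scatter.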

Compound 4, half-maximal inhibitory concentration: 46200 nM
The estimate for compound 4 lay 2.1-fold (0.31 log units) above the measured number; low and high end bracket the measured number.
By their numbers in this assay, from the lowest: compounds 4, 1, 3 and 2 (each within the scatter of the next, the first and the last beyond it).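

In this assay, for the compounds shown here, putting 3-(dimethylamino)propyl in place of hydrogen on this oxygen gives the one step at this position that clears the scatter, a 2.7-fold lower number from compound 2 to compound 4 (0.43 log units; beyond the scatter), so a chain on the oxygen can move the number by a modest but readable amount. The end of the chain is a different matter: changing hydrogen to methyl on the amine nitrogen gives a 2.0-fold lower number from compound 1 to compound 4 (0.29 log units; within the scatter), which means the chain ending in one methyl and the chain ending in two cannot be told apart in this assay. Nothing measured alongside these numbers bears on what lies behind the step from the free hydroxy group to the 3-(dimethylamino)propoxy group.

Going by these compounds, it remains open whether the amine is needed at all, since a plain propyl chain on the same oxygen would separate the effect of the nitrogen from that of the carbon chain. Also open, on these data alone, is how a shorter ethyl link, a longer butyl link or an amine held in a ring, such as piperidine or morpholine, would compare, and whether the same chain would act likewise on compound 3.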